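This account rests on a few compounds, and the source may have more. Where it says the series, first, only, none or still open, it means among the compounds named here.

Measured compounds:
compound 1 `CCC[C@@H](OC(C)=O)C1=C(Br)[C@@](C)(OC)OC1=O` — 10.7 ug/mL
compound 2 `CCC[C@@H](OC(C)=O)C1=C(Br)[C@@](CI)(OC)OC1=O` — 4.1 ug/mL
compound 3 `CCC[C@@H](OC(C)=O)C1=C(Br)[C@@](OC)(C(Br)Br)OC1=O` — 3.9 ug/mL

In a functional assay on KB cells (Homo sapiens) for cytotoxicity (a higher number here means that more compound is needed for the effect, a lower number that less compound is needed), compound 3 gives the lowest number of the three, though its gap to compound 2 is within the scatter; only the gap to compound 1 is beyond it. For the measured compounds named here, the one step with a single change, a 2.6-fold lower number from compound 1 to compound 2 (0.42 log units; beyond the scatter), is a modest move on a saturated chain carbon bound to a saturated ring carbon.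

Compound 4 `CCC[C@@H](OC(C)=O)C1=C(Br)[C@](OC)(C(Br)Br)OC1=O` is the next compound for this assay. The difference from compound 3 is the two compounds have the same atoms and bonds and differ only in configuration as drawn: 1 of 2 stereo elements differ; a stereocentre at a saturated ring carbon is drawn S in compound 3 and R in compound 4. No measured pair in the series differs only in configuration, so nothing among the shown steps bears on this change; the step from compound 1 to compound 2 concerns a substituent, not a stereocentre, and offers no guide. Going by the values given here, with no precedent, a change in this assay is expected to stay within the scatter, while the range is kept wide to allow for either direction. The expected step is a 1.2-fold higher number from compound 3 to compound 4 (0.06 log units; within the scatter). Compound 4 is therefore estimated at 4.5 ug/mL, with a range from 2 ug/mL to 11 ug/mL.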

Compound 4, concentration for half-maximal effect: 5.3 ug/mL
Estimate against measurement, compound 4: 1.2-fold (0.07 log units) below; the range from low to high includes it.
By their numbers in this assay, from the lowest: compounds 3, 2 and 4 (each within the scatter of the next); then compound 1.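

In this assay, inverting the stereocentre at the saturated ring carbon gives a 1.4-fold higher number from compound 3 to compound 4 (0.13 log units; within the scatter), so with dibromomethyl on this carbon the drawn configuration shows no effect that can be told from the scatter, and this pair reads configuration alone: the fact that compounds 3 and 4 differ only in the configuration as drawn With the centre drawn R, dibromomethyl in place of iodomethyl gives a 1.3-fold higher number from compound 2 to compound 4 (0.11 log units; within the scatter), so these two halogenated groups cannot be told apart in this assay, while dibromomethyl in place of methyl gives a 2.0-fold lower number from compound 1 to compound 4 (0.31 log units; beyond the scatter), a modest step. The lower number relative to the methyl group of compound 1 therefore holds for both compound 2 and compound 4, and neither of the two listed steps from compound 1 goes against it.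

The compounds shown leave open whether configuration at this ring carbon is equally silent with methyl or iodomethyl on it, and whether the second stereocentre matters at all. Also open, on these data alone, is how a hydroxymethyl group or a carboxylic acid on the same ring carbon would read, and whether any group there moves the number by more than these modest steps.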